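The source may report more compounds than this note shows. Statements on the series, on what has been measured and on what is new or still open speak of the compounds shown alone.

Measured so far:
compound 1, `COc1cc(-c2nn(-c3cccc(NC(=O)c4cccc(C(F)(F)F)c4)c3)cc2-c2ccncc2)ccc1Cl`: > 50000 nM
compound 2, `COc1cc(-c2nn(-c3cccc(NC(=O)Nc4ccc(Cl)c(C(F)(F)F)c4)c3)cc2-c2ccncc2)ccc1Cl`: > 32500 nM

Compound 1 has the structure `COc1cc(-c2nn(-c3cccc(NC(=O)c4cccc(C(F)(F)F)c4)c3)cc2-c2ccncc2)ccc1Cl`. In a functional assay on A549 cells (Homo sapiens) for inhibition, read by sulforhodamine B assay, with a stated time of 48 h (on this read-out higher numbers stand for lower toxicity in this test and lower numbers for higher toxicity in this test), compound 1 gives > 50000 nM, which is a limit of the assay rather than a number. Compound 2 has the structure `COc1cc(-c2nn(-c3cccc(NC(=O)Nc4ccc(Cl)c(C(F)(F)F)c4)c3)cc2-c2ccncc2)ccc1Cl`. In this assay compound 2 gives > 32500 nM, again a limit of the assay and not a number. Compound 2 thus stands at the limit of > 32500 nM in this assay, at which 1 of the 2 values shown sits, and the step that the two limits leave unreadable from compound 1 to compound 2 is left unreadable by the two limits.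

Compound 3, `COc1cc(-c2nn(-c3cccc(NC(=O)Nc4ccc(Cl)c(Cl)c4)c3)cc2-c2ccncc2)ccc1Cl`, differs from compound 2 by chloro in place of trifluoromethyl on an aromatic carbon. Among the measured compounds shown here, no measured step covers this exchange; the only measured step, a step that the two limits leave unreadable from compound 1 to compound 2, gives no size. With compound 2 at a limit and compound 1 at the limit of > 50000 nM in this assay, at which 1 of the 2 values shown sits, compound 3 is expected to stay in the same region. Compound 3 is expected to give 40000 nM in this assay, in a range from 15000 nM to 100000 nM. The expected step that the limit leaves unreadable from compound 2 to compound 3 is none beyond the scatter.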

Compound 3, concentration lethal to 50% of the cells: > 50000 nM
Compound 3 gave a limit, no number (the forecaster's own chance of this, stated with the estimate: 75%); middle value at least 1.2-fold (0.09 log units) away from the limit.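

Among the compounds shown here, compound 1, compound 2 and compound 3 all give limits rather than numbers in this assay, so no step between them can be read. The compounds shown leave open how toxic each one is, and whether chloro in place of trifluoromethyl changes that at all.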